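Thione-for-amine heterocycle swap on the sulfonyl biphenyl core

A few compounds are considered here, and "the series" means these few. Any claim that something is new, unique, unknown or untested is made for them only; others in the source may bear on it.

Compound 2 `Nc1nnc(-c2ccccc2S(=O)(=O)c2ccccc2)o1` gives 40.5% in a functional assay on the whole organism (strain NMRI) for inhibition, with Mus musculus as the target, in the formalin test, with a stated time of 30 min, at a dose of 30 umol/kg by the intraperitoneal route (a higher number here means more inhibition at the dose given (going by the name of the read-out), a lower number less inhibition), the lowest of the two numbers shown; its nearest neighbour is compound 1 `O=S(=O)(c1ccccc1)c1ccccc1-c1n[nH]c(=S)o1`, which gives 41.9% in this assay, a difference within the scatter. Compound 3 `O=S(=O)(c1ccccc1)c1ccccc1-c1n[nH]c(=S)[nH]1` carries a group of 6 heavy atoms (2 carbon, 3 nitrogen, 1 sulfur; one five-membered aromatic ring with 3 hetero atoms) in place of a group of 6 heavy atoms (2 carbon, 3 nitrogen, 1 oxygen; one five-membered aromatic ring with 3 hetero atoms), on an aromatic carbon. Among the measured compounds shown here, the one measured step that bears on it, a number 1.4 percentage points lower from compound 1 to compound 2 (within the scatter), also exchanged the whole five-membered ring on that aromatic carbon and stayed within the scatter, so no step beyond the scatter is expected here either. Compound 3 is therefore estimated at 41%, between 26% and 57%, a step of a number 0.5 percentage points higher from compound 2 to compound 3 (within the scatter) being expected.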

Compound 3, a percentage reported as inhibition, in the whole organism at one dose (the size of the read-out at that dose, not a potency): 31.2%
The estimate for compound 3 lay 9.8 percentage points above the measured number; the measured number falls inside the stated range.
By their numbers in this assay, from the lowest: compounds 3, 2 and 1 (each within the scatter of the next, the first and the last beyond it).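

In this assay, among the compounds shown here, the five-membered ring on this aromatic carbon is not wholly interchangeable: the entering group with 3 nitrogen and 1 sulfur gives a number 10.7 percentage points lower from compound 1 to compound 3 (beyond the scatter), the first step beyond the scatter. Against 5-amino-1,3,4-oxadiazol-2-yl, the same group gives a number 9.3 percentage points lower from compound 2 to compound 3 (within the scatter), so the separation rests on the comparison with compound 1 alone and is small. Open, on these data alone, is whether a carboxylic acid or an open-chain amine on this aromatic carbon would hold the level of compound 1. No measurement shown accounts for the difference.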